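The compounds below may be only part of what the source reports. "The series", "measured", "known", "first", "only" and "open" are said of these compounds alone.

Of the compounds shown here, three that share one core have been tested so far in a functional assay on KB cells (Homo sapiens) for cytotoxicity; on this read-out lower numbers stand for stronger inhibition and higher numbers for weaker inhibition. Compound 1 `COCCOCn1cc(C#N)c2c(N)ncnc21` carries a 2-methoxyethoxy group on a saturated chain carbon bound to an aromatic nitrogen. In this assay compound 1 gives > 100000 nM, which is a limit of the assay and not a number. Compound 2 `Cc1ccc(Cn2cc(C#N)c3c(N)ncnc32)cc1` gives > 100000 nM, again a limit. Compound 3 `Cc1ccccc1Cn1cc(C#N)c2c(N)ncnc21` gives > 100000 nM, also a limit. Compound 1 therefore stands at the limit of > 100000 nM in this assay, at which 3 of the 3 values shown sit, and no true number is available yet for any of the three.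

Compound 4 `Cn1cc(C#N)c2c(N)ncnc21` has not been measured. It differs from compound 1 by hydrogen in place of 2-methoxyethoxy on a saturated chain carbon bound to an aromatic nitrogen. Read one bond further out, this is (2-methoxyethoxy)methyl to methyl. Among the compounds with values here, no pair of measured compounds shows the size of such a change. The expectation starts from compound 1 at > 100000 nM, which is a limit. The step expected in this assay is a number no higher from compound 1 to compound 4 (the limit leaves the size open), which means none beyond the scatter. For compound 4 the estimated value is 100000 nM, with an expected range from 40000 nM to 100000 nM.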

Compound 4, half-maximal inhibitory concentration: > 100000 nM
Compound 4: no number, only a limit; the forecaster's own chance of this, stated with the estimate: 85%; the middle value lies on the limit itself.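

Compound 4 gives > 100000 nM in this assay, which is a limit of the assay and not a number. Within the data shown here, no step from compound 1 to compound 4 can be read, since both values are limits. All four compounds sit at one limit, so the compounds shown leave open what real number, if any, each would reach: the limit of > 100000 nM in this assay, at which 4 of the 4 values shown sit.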